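The source may report more compounds than this note shows. Statements on the series, on what has been measured and on what is new or still open speak of the compounds shown alone.

Within the data shown here, in a functional assay on SK-OV-3 cells (Homo sapiens) for antiproliferative activity, read by MTT assay, with a stated time of 72 h (on this read-out lower numbers stand for stronger inhibition and higher numbers for weaker inhibition), two compounds built on a shared core have numbers so far. Compound 1 `CC(C)c1cccc(NC(=O)CCc2cccc3c2B(O)OC3)c1` gives 510 nM as the lower of the two and so shows the stronger inhibition. Compound 2 `O=C(CCc1cccc2c1B(O)OC2)Nc1ccccc1-c1ccccc1` gives 26000 nM and that gap lies well beyond the scatter of repeat measurements. Compound 3 `COc1ccc(-c2cccc(NC(=O)CCc3cccc4c3B(O)OC4)c2)cc1` keeps the core of compound 1 and alters a single group: 4-methoxyphenyl in place of isopropyl on an aromatic carbon with 4-methoxyphenyl in place of isopropyl on an aromatic carbon, meta to a large group. Among the measured compounds shown here, no measured pair shows this kind of change, so the expectation is a loose one: a moderate loss of inhibition, beyond the scatter. The estimated size of this move is a 2.9-fold higher number from compound 1 to compound 3 (0.47 log units; beyond the scatter) towards a higher number. For compound 3 the expected value is 1500 nM with an estimated range from 300 nM to 8000 nM in this test.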

Compound 3, half-maximal inhibitory concentration: 48 nM
Estimate against measurement, compound 3: 31-fold (1.49 log units) above, and the stated range ends above it.
By their numbers in this assay, from the lowest: compound 3; then compound 1; then compound 2.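

In this assay, among these compounds, putting 4-methoxyphenyl in place of isopropyl gives an 11-fold lower number from compound 1 to compound 3 (1.03 log units; beyond the scatter), a large step and the first comparison here between compounds that differ in one place. It shows that this aromatic carbon, meta to a large group, can carry a much bigger group than isopropyl, with 8 heavy atoms instead of 3, and that the number falls rather than rises. No measured property of these compounds accounts for this gain.

The compounds shown do not separate the contribution of the aromatic ring from that of its methoxy group, which plain phenyl at this carbon could help to resolve. Going by these compounds, it also remains open how a ring carrying an amine or a carboxylic acid in place of the methoxy group would behave here.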